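Ethyl Extension and Cytotoxicity: Working Notes on the Series

This account rests on a few compounds, and the source may have more. Where it says the series, first, only, none or still open, it means among the compounds named here.

Three measured compounds share a core carrying a saturated chain. Compound 3 `CCCCCCCCCCOc1ncnc2c1ncn2CC(=O)OCC` holds that chain on an oxygen; compound 1 `CCCCCCCCCCCCOc1ncnc2c1ncn2CC(=O)OCC` differs from it by ethyl in place of hydrogen on a saturated chain carbon, ten or more bonds along the chain from an oxygen on an aromatic ring; compound 2 `CCCCCCCCCCSc1ncnc2c1ncn2CC(=O)OCC` holds a chain on a sulfur, and the difference between the cores of compound 2 and compound 3 is not broken down here. In an ADME assay on Vero cells (Chlorocebus sabaeus) for cytotoxicity (on this read-out lower numbers stand for higher toxicity in this test and higher numbers for lower toxicity in this test), compound 3 reaches only a limit, > 62.5 ug/mL. In this assay compound 1 also stops at a limit, > 10 ug/mL. Compound 2 likewise gives a limit, > 62.5 ug/mL. The step that the two limits leave unreadable from compound 3 to compound 1 stays unreadable because one value sits at the limit of > 10 ug/mL in this assay, at which 1 of the 3 values shown sits, while the others sit at the limit of > 62.5 ug/mL in this assay, at which 2 of the 3 values shown sit.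

Compound 4 `CCCCCCCCCCCCSc1ncnc2c1ncn2CC(=O)OCC` is not yet measured in this assay. It differs from compound 2 by ethyl in place of hydrogen on a saturated chain carbon, ten or more bonds along the chain from a sulfur, the same kind of change as from compound 3 to compound 1, the chain here running from a sulfur instead of from an oxygen on an aromatic ring. The step of an at least 1.2-fold lower number from compound 2 to compound 4 (0.09 log units; that floor lies within the scatter) is expected to be small, resting on the unreadable step that the two limits leave unreadable from compound 3 to compound 1. Compound 4 is estimated at about 50 ug/mL, between 15 ug/mL and 100 ug/mL.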

Compound 4, half-maximal cytotoxic concentration: > 10 ug/mL
Compound 4 gave a limit, no number; the forecaster's own chance of this, stated with the estimate: 60%; the middle value lies beyond the limit too.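

In this assay, for the compounds shown here, compound 4 gives only a limit, > 10 ug/mL, and no new step from compound 2 to it can be read. The compounds shown leave open whether ethyl in place of hydrogen on the saturated chain changes the read-out at all, on either the sulfur or the oxygen chain.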